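Para substituent on the shared core: from fluoro to acetyl

The source may hold more compounds than are shown below. What is called first, only, known or untested is meant among the compounds shown, and "the series" means these compounds.

In a functional assay on KM12 cells (Homo sapiens) for inhibition, read by sulforhodamine B assay, with a stated time of 48 h, tested at 10 uM (a higher number here means more inhibition at the concentration tested (going by the name of the read-out), a lower number less inhibition), compound 1 `COc1ccc(-c2cn3ccnc3c(-c3ccc4ncn(C5CCCCC5)c4c3)n2)cc1` gives 83.2%, compound 2 `O=Cc1ccc(-c2cn3ccnc3c(-c3ccc4ncn(C5CCCCC5)c4c3)n2)cc1` gives 3.69%, and compound 3 `Fc1ccc(-c2cn3ccnc3c(-c3ccc4ncn(C5CCCCC5)c4c3)n2)cc1` gives 3.49%. Compound 3 stands lowest of the three, yet its gap to compound 2 is within the scatter, while the step of a number 79.7 percentage points lower from compound 1 to compound 3 (beyond the scatter) is large. Compound 4 `CC(=O)c1ccc(-c2cn3ccnc3c(-c3ccc4ncn(C5CCCCC5)c4c3)n2)cc1` differs from compound 3 by acetyl in place of fluoro on an aromatic carbon. The bearing step is a number 0.2 percentage points lower from compound 2 to compound 3 (within the scatter), where one carbonyl-bearing group stood in for fluoro without a change beyond the scatter; the drop a number 79.5 percentage points lower from compound 1 to compound 2 (beyond the scatter) shows the methoxy compound alone apart. The change is therefore expected to give no step beyond the scatter, a number 4.5 percentage points higher from compound 3 to compound 4 (within the scatter). Compound 4 is estimated at 8%, within 0% to 35%.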

Compound 4, a percentage reported as inhibition, at one concentration (the size of the read-out at that concentration, not a potency): 11.7%
Estimate against measurement, compound 4: 3.7 percentage points below; the measured number falls inside the stated range.
By their numbers in this assay, from the lowest: compounds 3, 2 and 4 (each within the scatter of the next); then compound 1.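

In this assay, acetyl at this place, para to a large group, does not separate from fluoro: a number 8.2 percentage points higher from compound 3 to compound 4 (within the scatter). Methyl in place of hydrogen on the carbonyl carbon also leaves the number within the scatter, a number 8 percentage points higher from compound 2 to compound 4 (within the scatter), while compound 1 again stands apart, a number 71.5 percentage points lower from compound 1 to compound 4 (beyond the scatter), so among these four compounds the high number occurs only with methoxy. No evidence is available to explain this separation.

As far as these compounds go, whether the high number is specific to methoxy remains open. Ethoxy, hydroxy or a dimethylamino group at this place would test this.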